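Chloro in place of fluoro: expectation for compound 3

A few compounds are considered here, and "the series" means these few. Any claim that something is new, unique, unknown or untested is made for them only; others in the source may bear on it.

In a functional assay on MCF7 cells (Homo sapiens) for antiproliferative activity, read by MTT assay, with a stated time of 72 h (a higher number here means a weaker inhibitor, a lower number a stronger inhibitor), compound 2 (`O=S(=O)(Oc1ccc(F)cc1)C1CC2OC1C(c1ccc(/C=C/c3cc(O)cc(O)c3)cc1)=C2c1ccc(O)cc1`) gives 13100 nM and compound 1 (`O=S(=O)(Oc1ccc(Br)cc1)C1CC2OC1C(c1ccc(/C=C/c3cc(O)cc(O)c3)cc1)=C2c1ccc(O)cc1`) gives 16900 nM within the scatter of each other. Compound 3 (`O=S(=O)(Oc1ccc(Cl)cc1)C1CC2OC1C(c1ccc(/C=C/c3cc(O)cc(O)c3)cc1)=C2c1ccc(O)cc1`) has chloro in place of fluoro on an aromatic carbon, para to a large group (chloro in place of fluoro on an aromatic carbon). Among the compounds with values here, the one measured step bearing on this, fluoro in place of bromo on an aromatic carbon, is a 1.3-fold lower number from compound 1 to compound 2 (0.11 log units; within the scatter) and stays within the scatter, so no step beyond the scatter is expected in this assay for this change. The estimated value for compound 3 is 15000 nM (range 8000 nM to 28000 nM). That estimate means a 1.1-fold higher number from compound 2 to compound 3 (0.06 log units; within the scatter) as the expected step within the scatter.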

Compound 3, half-maximal inhibitory concentration: 17900 nM
For compound 3 the middle estimate is 1.2-fold (0.08 log units) below the measured one; low and high end bracket the measured number.
By their numbers in this assay, from the lowest: compounds 2, 1 and 3 (each within the scatter of the next).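

In this assay the change from fluoro to chloro gives a 1.4-fold higher number from compound 2 to compound 3 (0.14 log units; within the scatter) and the change from bromo to chloro gives a 1.1-fold higher number from compound 1 to compound 3 (0.02 log units; within the scatter), so all three halogens now read on this aromatic carbon, para to a large group, fall within the scatter of each other. Across fluoro, chloro and bromo, this position therefore shows no separation in this assay. No measured evidence speaks to the reason for this. Still open, going by these compounds, is whether a group other than a halogen at this place, such as an amine, a carboxylic acid or a longer chain, would move the number beyond the scatter.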